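This account rests on a few compounds, and the source may have more. Where it says the series, first, only, none or still open, it means among the compounds named here.

In a functional assay on U-937 cells (Homo sapiens) for antiproliferative activity, read by MTT assay, with a stated time of 24 h (on this read-out higher numbers stand for weaker inhibition and lower numbers for stronger inhibition), compound 1 `CCCCc1oc2ccccc2c1C(=O)c1ccc(OCC(=O)N2CCCC2)cc1` gives 32500 nM and compound 2 `CCCCc1oc2ccccc2c1C(=O)c1ccc(OCCCC(=O)N2CCCCC2)cc1` gives 16600 nM, so compound 2 stands within the scatter of compound 1. Compound 3 `CCCCc1oc2ccccc2c1C(=O)c1ccc(OCCCC(=O)N2CCOCC2)cc1` carries morpholin-4-yl in place of piperidin-1-yl on a carbonyl carbon. Among the compounds with values here, the only measured step, a 2.0-fold lower number from compound 1 to compound 2 (0.29 log units; within the scatter), lies within the scatter and does not involve morpholin-4-yl, so it offers only weak guidance. The expected change, a 1.5-fold higher number from compound 2 to compound 3 (0.18 log units; within the scatter), is estimated to stay within the scatter, with no firm direction. For compound 3 the estimated value in this assay is 25000 nM, with an expected range from 10000 nM to 60000 nM.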

Compound 3, half-maximal inhibitory concentration: 21400 nM
The estimate for compound 3 lay 1.2-fold (0.07 log units) above the measured number, within the range that was stated.
By their numbers in this assay, from the lowest: compounds 2, 3 and 1 (each within the scatter of the next).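

In this assay morpholin-4-yl in place of piperidin-1-yl on a carbonyl carbon gives a 1.3-fold higher number from compound 2 to compound 3 (0.11 log units; within the scatter) and so, at this position, the entering ring oxygen and its hydrogen-bond acceptor leave the number within the scatter. The wider swap of (pyrrolidin-1-yl)carbonyl for 2-((morpholin-4-yl)carbonyl)ethyl gives a 1.5-fold lower number from compound 1 to compound 3 (0.18 log units; within the scatter) and so does not separate these compounds either. No measurement bearing on the reason for these numbers is available. Still open, from the compounds shown here alone, is whether piperazin-1-yl on the carbonyl carbon, or a carboxylic acid in place of the amide, would give a step beyond the scatter.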